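Removing One Methyl Group from the Core of Compound 1

A few compounds are considered here, and "the series" means these few. Any claim that something is new, unique, unknown or untested is made for them only; others in the source may bear on it.

Compound 1 `COc1cccc(-c2cc(O)c3c(C)cc(C)nc3n2)c1` — 437 nM
Compound 2 `COc1ccccc1-c1cc(O)c2ccc(C)nc2n1` — > 100000 nM

Within the data shown here, in a functional assay on 786-0 cells (Homo sapiens) (a higher number here means a weaker inhibitor of growth, a lower number a stronger inhibitor of growth), compound 1 gives 437 nM, the only plain number among the measured compounds. For compound 2 the assay reports > 100000 nM, which is a limit of the assay rather than a measured number. Compound 2 sits at the limit of > 100000 nM in this assay, at which 1 of the 2 values shown sits. Among the measured compounds shown here, compounds 1 and 2 differ in several places at once, so no single step between them is set out; their two values show only that compound 1 inhibits growth at a measurable concentration while compound 2 does not within the tested range.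

Compound 3 `COc1cccc(-c2cc(O)c3c(C)ccnc3n2)c1` has not yet been measured. It differs from compound 1 by hydrogen in place of methyl on an aromatic carbon. For the measured compounds named here, no measured pair shows a change of this kind, so the size of the step is uncertain. The step of a 1.8-fold higher number from compound 1 to compound 3 (0.26 log units; within the scatter) is expected to be small, leaning toward weaker inhibition, or to stay within the scatter. For compound 3 the estimate in this assay is 800 nM, with a range from 250 nM to 3000 nM.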

Compound 3, concentration for 50% growth inhibition: 51.3 nM
For compound 3 the middle estimate is 16-fold (1.19 log units) above the measured one, and the stated range ends above it.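

This is the first comparison among the compounds shown that changes only one place, and it reads clearly: in this assay, hydrogen in place of the methyl group next to the ring nitrogen gives an 8.5-fold lower number from compound 1 to compound 3 (0.93 log units; beyond the scatter), a step beyond the usual scatter. Since a lower number here means stronger growth inhibition, this methyl group is not needed for activity in the core of compound 1, and compound 3 is the stronger inhibitor without it. The change is small, only one carbon atom leaving, yet the step is clear.

Going by these compounds, whether a longer chain such as ethyl, or an amine, at this same position would behave more like methyl or more like hydrogen remains open. Nothing shown here accounts for the direction or size of this step.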